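Chloro in place of hydrogen on the phenyl of compound 1

The source may report more compounds than this note shows. Statements on the series, on what has been measured and on what is new or still open speak of the compounds shown alone.

Measured compounds:
compound 1, `COc1cc(N/C=C\C(=O)c2cn(-c3ccccc3)nc2-c2ccccc2)cc(OC)c1OC`: 36200 nM
compound 2, `O=C(/C=C\Nc1ccc(F)cc1)c1cn(-c2ccccc2)nc1-c1ccc(Cl)cc1`: > 50000 nM

Two compounds sharing one core have been examined in an ADME assay on HaCaT cells (Homo sapiens) for antiproliferative activity, read by MTT assay, with a stated time of 48 h; a higher number here means a weaker inhibitor, a lower number a stronger inhibitor. For the measured compounds named here, compound 1 gives 36200 nM, the only plain number among the two values. For compound 2 the result is a limit of the assay, > 50000 nM. Compound 1 therefore stands as the single measured point, with the other value sitting at the limit of > 50000 nM in this assay, at which 1 of the 2 values shown sits. Going by the values given here, the two compounds differ in more than one place, so their values show only that one is a number and the other a limit.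

Compound 3, `COc1cc(N/C=C\C(=O)c2cn(-c3ccccc3)nc2-c2ccc(Cl)cc2)cc(OC)c1OC`, is not yet measured. It differs from compound 1 by chloro in place of hydrogen on an aromatic carbon. Among the compounds with values here, no single step between measured compounds is available to set the size of this change. The writer expects compound 3 to behave much like compound 1, with a step of a 1.2-fold higher number from compound 1 to compound 3 (0.06 log units; within the scatter) in this assay, which is within the usual scatter or at most slightly toward weaker inhibition. Compound 3 is estimated at 42000 nM, within a range from 15000 nM to 120000 nM, with a fair chance that only a limit is reported.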

Compound 3, half-maximal inhibitory concentration: 46600 nM
Compound 3: middle estimate off by 1.1-fold (0.05 log units), on the low side, within the range that was stated.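

Going from phenyl to 4-chlorophenyl gives the first comparison in this assay between compounds that differ in one place, and the step is a 1.3-fold higher number from compound 1 to compound 3 (0.11 log units; within the scatter). Chloro in place of hydrogen at this aromatic carbon, para to a large group, therefore leaves compound 3 and compound 1 indistinguishable in this read-out, and both remain plain numbers that can be set side by side. Compound 2, which also carries the 4-chlorophenyl, is reported only as a limit and not as a number, so no step involving it can be read: the limit of > 50000 nM in this assay, at which 1 of the 3 values shown sits.

This single step leaves open whether other groups at the same position, such as an amine, a carboxylic acid or a longer chain like butyl, would also stay within the scatter of compound 1, or whether they would move the value in either direction. It also leaves open whether chloro at this place would read the same on a compound whose other aromatic ring carries a dimethylamino group in place of the methoxy groups of compound 1.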